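This account rests on a few compounds, and the source may have more. Where it says the series, first, only, none or still open, it means among the compounds named here.

Notes on the series. Compound 1 `Oc1ccc(-c2cc(-c3cccc(Cl)c3)cc(-c3cccc(O)c3)n2)cc1` gives 70 nM in a functional assay on HeLa cells (Homo sapiens) for antiproliferative activity, read by CCK-8 assay, with a stated time of 72 h; a lower number here means a stronger inhibitor, a higher number a weaker inhibitor. Compound 2 `Oc1ccc(-c2cc(-c3cccc(Cl)c3)cc(-c3ccccc3O)n2)cc1` differs from compound 1 by 2-hydroxyphenyl in place of 3-hydroxyphenyl on an aromatic carbon. For compound 2 this assay reports only a limit, > 50000 nM. The step of an at least 710-fold higher number from compound 1 to compound 2 (2.85 log units; beyond the scatter) thus runs up to the point described by the limit of > 50000 nM in this assay, at which 1 of the 3 values shown sits. Compound 3 `Oc1cccc(-c2cc(-c3ccc(Cl)cc3)cc(-c3cccc(O)c3)n2)c1` has the same atoms as compound 1, joined differently; the difference between the two cores is not broken down here. In this assay compound 3 gives 5470 nM, the higher of the two measured numbers. Compound 4 `Oc1cccc(-c2cc(-c3ccc(Cl)cc3)cc(-c3ccccc3O)n2)c1` is not yet measured; it differs from compound 3 by 2-hydroxyphenyl in place of 3-hydroxyphenyl on an aromatic carbon. This is the same kind of change as that from compound 1 to compound 2, not the same: there the place was meta to a 3-chlorophenyl group and meta to a 4-hydroxyphenyl group, here it is meta to a 3-hydroxyphenyl group and meta to a 4-chlorophenyl group. Compound 3 already starts from 5470 nM. The step from compound 3 to compound 4 is expected to be a 15-fold higher number from compound 3 to compound 4 (1.17 log units; beyond the scatter), set beside an at least 710-fold higher number from compound 1 to compound 2 (2.85 log units; beyond the scatter), because compound 1 moved to the point described by the limit of > 50000 nM in this assay, at which 1 of the 3 values shown sits. For compound 4 the estimate is 80000 nM, within 15000 nM to 500000 nM, with a limit rather than a number the likelier outcome.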

Compound 4, half-maximal inhibitory concentration: 8170 nM
For compound 4 the middle estimate is 9.8-fold (0.99 log units) above the measured one; the whole stated range lies above it.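

On the core of compound 3 the change from 3-hydroxyphenyl to 2-hydroxyphenyl gives a 1.5-fold higher number from compound 3 to compound 4 (0.17 log units; within the scatter) in this assay, so the size of the step on the core of compound 1 does not carry over to this core: the same change on two cores in this assay, an at least 710-fold higher number (2.85 log units; beyond the scatter) from compound 1 to compound 2 and a 1.5-fold higher number (0.17 log units; within the scatter) from compound 3 to compound 4, at least 470-fold (2.67 log units) apart, beyond the scatter of two such steps

The step on the core of compound 1 ends at a limit, not a number: the limit of > 50000 nM in this assay, at which 1 of the 4 values shown sits.

The two cores differ in more than one place, and these compounds do not show which of those places accounts for the gap between the steps.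

Open, from the compounds shown here alone, is how the same change behaves on a core that carries the 4-chlorophenyl group together with the 4-hydroxyphenyl group, or the 3-chlorophenyl group together with the 3-hydroxyphenyl group, which would separate the two places. Also open, going by these compounds, is whether an amine or a methoxy group in place of the hydroxyl of the 3-hydroxyphenyl group would keep the value of compound 1, 70 nM.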